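Aryl ester variation on the shared core, toward compound 4

This account rests on a few compounds, and the source may have more. Where it says the series, first, only, none or still open, it means among the compounds named here.

Measured so far in an assay on HEK293T cells for inhibition of nuclear factor NF-kappa-B complex (Homo sapiens), read by a luciferase reporter; a lower number here means a stronger inhibitor, a higher number a weaker inhibitor:
compound 1 `COc1cc2c(c(O)c1C(=O)/C=C/c1ccc(OC(=O)C3CCC3)cc1)CCC(C)(C)O2` — > 30000 nM
compound 2 `COc1cc2c(c(O)c1C(=O)/C=C/c1ccc(OC(=O)c3ccc(Cl)nc3)cc1)CCC(C)(C)O2` — > 30000 nM
compound 3 `COc1cc2c(c(O)c1C(=O)/C=C/c1ccc(OC(=O)c3ccccc3F)cc1)CCC(C)(C)O2` — > 30000 nM

Every value here is a limit of the assay, not a number. Compound 3 sits at the limit of > 30000 nM in this assay, at which 3 of the 3 values shown sit, together with the other two. The three measured steps, a step that the two limits leave unreadable from compound 1 to compound 2, a step that the two limits leave unreadable from compound 1 to compound 3 and a step that the two limits leave unreadable from compound 2 to compound 3, all change the group on the carbonyl carbon of the ester, and none can be read in size because the limit of > 30000 nM in this assay, at which 3 of the 3 values shown sit, covers both ends of each pair. The series therefore shows no readable movement in this assay among any of the ester variants tried.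

Compound 4 `COc1cc2c(c(O)c1C(=O)/C=C/c1ccc(OC(=O)c3cccc(Br)c3)cc1)CCC(C)(C)O2` carries the change (3-bromophenyl in place of 2-fluorophenyl on a carbonyl carbon). The measured steps bear on it only in kind, as further aryl exchanges at the same carbonyl carbon, and give no size. Compound 4 is expected to give in this assay an estimate of 40000 nM, between 10000 nM and 150000 nM. The step that the limit leaves unreadable from compound 3 to compound 4 this estimate implies is expected to stay unreadable against the limit of compound 3.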

Compound 4, half-maximal inhibitory concentration: > 30000 nM
Compound 4 gave a limit, no number; the forecaster's own chance of this, stated with the estimate: 80%; the middle value does not contradict the limit.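

Compound 4 gives > 30000 nM in this assay, a limit of the assay and not a number. No step from compound 1, compound 2 or compound 3 to compound 4 can be read in size: the limit of > 30000 nM in this assay, at which 4 of the 4 values shown sit.

The compounds shown leave open whether any ester group on the shared core gives a measurable value in this assay.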